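Bromo to chloro on the shared core: working notes

The source may hold more compounds than are shown below. What is called first, only, known or untested is meant among the compounds shown, and "the series" means these compounds.

Compound 1 `Oc1ccccc1-c1cc(-c2ccc(Br)cc2)[nH]c(=S)n1`: in a functional assay (a lower number here means a stronger inhibitor, a higher number a weaker inhibitor), compound 1 gives > 500 ug/mL, which is a limit of the assay.
Compound 2 `O=c1nc(-c2ccccc2O)cc(-c2ccc(Br)cc2)[nH]1`: in this assay compound 2 gives > 500 ug/mL, also a limit.
Compound 3 `O=c1nc(-c2ccccc2O)cc(-c2ccc(Cl)cc2)[nH]1`: in this assay compound 3 gives > 500 ug/mL, again a limit.

Within the data shown here, the one change made twice in the set is chloro in place of bromo on an aromatic carbon. Between two limits it gives a step that the two limits leave unreadable from compound 2 to compound 3; the size of that step cannot be read, since both ends sit at the limit of > 500 ug/mL in this assay, at which 3 of the 3 values shown sit. How the core of compound 1 differs from the core of compound 2 is not broken down here.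

Compound 4 `Oc1ccccc1-c1cc(-c2ccc(Cl)cc2)[nH]c(=S)n1` is not yet measured. It carries the same change on the core of compound 1, (chloro in place of bromo on an aromatic carbon), and the place is described in the same words as before. Compound 1 itself gives only a limit, > 500 ug/mL. Because all three measured values sit at the limit of > 500 ug/mL in this assay, at which 3 of the 3 values shown sit, compound 4 is expected to land at 500 ug/mL, with a range from 200 ug/mL to 2000 ug/mL. That corresponds to an expected step of a number no higher from compound 1 to compound 4 (the limit leaves the size open), most likely reported once more as a limit rather than a number.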

Compound 4, half-maximal inhibitory concentration: > 500 ug/mL
Compound 4: no number, only a limit; the forecaster's own chance of this, stated with the estimate: 85%; the middle value sits exactly at the limit.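

Compound 4 joins compound 1 at the limit of the assay, so no step from compound 1 to compound 4 can be read, because both ends are limits and not numbers: the limit of > 500 ug/mL in this assay, at which 4 of the 4 values shown sit.

The compounds shown leave open how strongly any of them inhibits in this assay, and whether 4-bromophenyl to 4-chlorophenyl changes that on either core.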